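The compounds below may be only part of what the source reports. "The series", "measured", "known", "first", "only" and "open" are said of these compounds alone.

Measured so far:
Compound 1, `CC(C)C[C@@H](C(=O)O)N1C(=O)/C(=C/c2ccc(Br)cc2)SC1=S`, gives 7430 nM in an assay on isolated protein for displacement of a labelled ligand from Apoptosis regulator Bcl-2 (Homo sapiens), read by fluorescence polarization; a higher number here means a weaker inhibitor, a lower number a stronger inhibitor.
Compound 2, `CC(C)C[C@@H](C(=O)O)N1C(=O)C(=C(c2ccccc2)c2ccccc2)SC1=S`, gives 57800 nM in this assay.

Of these two numbers, the value of compound 2 is the higher one, which means the weaker binding; the gap to compound 1 lies beyond the usual scatter, so compound 2 stands as the weaker of the two. Compound 3, `CC(C)C[C@@H](C(=O)O)N1C(=O)/C(=C(\c2ccccc2)c2ccc(-c3ccccc3)cc2)SC1=S`, shares the core of compound 2 and differs from it in one place: phenyl in place of hydrogen on an aromatic carbon. Within the data shown here, no pair among the measured compounds shows what such a change does on this core, so there is nothing to lean on beyond the two values already given. The step of a 1.9-fold lower number from compound 2 to compound 3 (0.28 log units; within the scatter) is therefore expected to be small, pointing toward slightly stronger binding but not clearly beyond the scatter. Compound 3 is expected to give about 30000 nM in this assay, with a plausible range from 8000 nM to 100000 nM.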

Compound 3, inhibition constant: 1950 nM
Compound 3: middle estimate off by 15-fold (1.19 log units), on the high side, outside the stated range (below it).
By their numbers in this assay, from the lowest: compound 3; then compound 1; then compound 2.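

Phenyl in place of hydrogen on an aromatic carbon, para to a large group, gives a 30-fold lower number from compound 2 to compound 3 (1.47 log units; beyond the scatter) in this assay. Among these compounds, this is the first comparison in which only one place changes, and it shows that this position on the shared core is far from indifferent: here, adding one six-membered aromatic ring of carbon only goes with much stronger binding. Nothing available explains why this single change has so large an effect.

A single step cannot tell whether an aromatic ring is needed here, or whether a cyclohexyl ring or a longer alkyl chain at the same place would serve as well. It also leaves open whether the outer phenyl can carry further groups, such as an amine or a carboxylic acid, and keep the stronger binding.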